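Bromo on the Benzyl Arm: Cytotoxicity Expectation for Compound 3

The source may report more compounds than this note shows. Statements on the series, on what has been measured and on what is new or still open speak of the compounds shown alone.

Compound 2 `O=C1N(Cc2ccccc2Cl)c2cccn2S(=O)(=O)N1Cc1ccccc1` is the plain benzyl member of the pair measured in an ADME assay on MT4 cells (Homo sapiens) for cytotoxicity, read by MTT assay, with a stated time of 5 days; a higher number here means that more compound is tolerated, a lower number that less compound is tolerated. For compound 2 this assay reports only a limit, > 291000 nM, and not a number. Its fluoro partner compound 1 `O=C1N(Cc2ccccc2Cl)c2cccn2S(=O)(=O)N1Cc1cccc(F)c1` gives 231000 nM in this assay. The step of an at least 1.2-fold higher number from compound 1 to compound 2 (0.10 log units; that floor lies within the scatter) lies within the scatter. Because compound 2 sits at the limit of > 291000 nM in this assay, at which 1 of the 2 values shown sits, where compound 2 truly stands is known only as a floor.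

Compound 3 `O=C1N(Cc2ccccc2Cl)c2cccn2S(=O)(=O)N1Cc1cccc(Br)c1` differs from compound 2 by bromo in place of hydrogen on an aromatic carbon. Among the measured compounds shown here, the only measured step at this place, an at least 1.2-fold higher number from compound 1 to compound 2 (0.10 log units; that floor lies within the scatter), runs in the opposite direction with fluoro and shows no movement beyond the scatter, so a halogen there gave no sign of altering how much compound is tolerated in this assay. A shift within the scatter, in either direction, is therefore expected for compound 3, amounting to an estimated step of an at least 1.1-fold lower number from compound 2 to compound 3 (0.06 log units; that floor lies within the scatter). Compound 3 is expected to give about 250000 nM in this assay, within a range from 110000 nM to 450000 nM, with a fair chance that only a limit is reported.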

Compound 3, half-maximal cytotoxic concentration: > 260000 nM
Compound 3: a limit, no number; the forecaster's own chance of this, stated with the estimate: 45%; middle value at least 1.0-fold (0.01 log units) away from the limit.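

In this assay compound 3 gives only a limit, > 260000 nM, and not a number. At this position bromo thus joins hydrogen in reaching a limit, which fluoro in compound 1 did not, while the change from fluoro to bromo gives an at least 1.1-fold higher number from compound 1 to compound 3 (0.05 log units; that floor lies within the scatter), so this exchange of one halogen for another shows no movement that can be told from repeated measurement. Compound 2 and compound 3 both stop at limits, so the step between them cannot be read: the limit of > 260000 nM in this assay, at which 1 of the 3 values shown sits.

The compounds shown leave open how far the true values of compound 2 and compound 3 lie past their limits, and so whether hydrogen and bromo differ at all in this assay. They also leave open whether a group of another kind at this position, such as an amine or a carboxylic acid, would move the tolerated concentration beyond the scatter, since only hydrogen and two halogens are seen here.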